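A Pyridin-4-yl Replaces 2,4-Difluorophenyl on the Amine Arm

The source may hold more compounds than are shown below. What is called first, only, known or untested is meant among the compounds shown, and "the series" means these compounds.

Measured compounds:
compound 1 `Cn1c(=O)c2[nH]c(-c3ccc(S(=O)(=O)N4CCN(Cc5ccc(Cl)s5)CC4)cc3)cc2n(C)c1=O` – 4 nM
compound 2 `Cn1c(=O)c2[nH]c(-c3ccc(S(=O)(=O)N4CCN(Cc5ccc(F)cc5F)CC4)cc3)cc2n(C)c1=O` – 7 nM

Two compounds share the core and the sulfonyl-linked ring amine; they differ only in the aromatic group on the saturated chain carbon bound to that amine nitrogen. In an assay on HEK293 cells for displacement of a labelled ligand from adenosine receptor A2b (Homo sapiens) (a lower number here means a stronger inhibitor, a higher number a weaker inhibitor), compound 1 gives 4 nM, and compound 2 gives 7 nM. Among the measured compounds shown here, compound 2 carries the highest of the two numbers, but its only neighbour is compound 1, and a 1.8-fold higher number from compound 1 to compound 2 (0.24 log units; within the scatter), so the two stand level.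

Compound 3 `Cn1c(=O)c2[nH]c(-c3ccc(S(=O)(=O)N4CCN(Cc5ccncc5)CC4)cc3)cc2n(C)c1=O` is the next member. Its change from compound 2 is pyridin-4-yl in place of 2,4-difluorophenyl on a saturated chain carbon bound to an amine nitrogen in a ring. For the measured compounds named here, the one measured step that bears on this position is a 1.8-fold higher number from compound 1 to compound 2 (0.24 log units; within the scatter), an exchange of one aromatic group for another at the same carbon that left this assay essentially unmoved. On that basis the author expects a 1.7-fold higher number from compound 2 to compound 3 (0.23 log units; within the scatter), a step no larger than the scatter, with a slight lean toward a higher number. Compound 3 is therefore estimated at 12 nM, within a range of 4 nM to 40 nM.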

Compound 3, half-maximal inhibitory concentration: 27 nM
Beside the measured number, compound 3's estimate is 2.3-fold (0.35 log units) below it; the measured number falls inside the stated range.
By their numbers in this assay, from the lowest: compounds 1 and 2 (each within the scatter of the next); then compound 3.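

In this assay this position turns out not to accept every aromatic group alike: pyridin-4-yl in place of 2,4-difluorophenyl gives a 3.9-fold higher number from compound 2 to compound 3 (0.59 log units; beyond the scatter), and in place of 5-chlorothiophen-2-yl it gives a 6.8-fold higher number from compound 1 to compound 3 (0.83 log units; beyond the scatter), whereas the exchange between the first two groups stayed within the scatter. The change from compound 2 to compound 3 removes both fluorine atoms and brings in a ring nitrogen that counts as a hydrogen-bond acceptor, and this single step cannot separate the two. Nothing available gives a measured reason for the step.

The compounds shown leave open whether the ring nitrogen or the loss of fluorine matters more. They also do not tell how an unsubstituted phenyl or a pyridin-3-yl group would read at this same carbon.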